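Pyridine in place of pyrazole: expected microsomal clearance

The compounds below may be only part of what the source reports. "The series", "measured", "known", "first", "only" and "open" are said of these compounds alone.

Compound 1 `CNC(=O)c1ncc(-c2cnc(NCc3c(F)ccc4c3CCO4)c3cn[nH]c(=O)c23)n1C` gives 24 mL.min-1.g-1 in an ADME assay on microsomes from liver (Homo sapiens) for metabolic stability, read by LC-MS, using NADPH, with stated times of 5 min and 30 min, tested at 1 uM; on this read-out lower numbers stand for slow clearance and higher numbers for fast clearance.
Compound 2 `Cn1nccc1-c1cnc(NCc2c(F)ccc3c2CCO3)c2cn[nH]c(=O)c12` gives 14 mL.min-1.g-1 in this assay.
Compound 3 `Cc1nn(C)cc1-c1cnc(NCc2c(F)ccc3c2CCO3)c2cn[nH]c(=O)c12` gives 27 mL.min-1.g-1 in this assay.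

Compound 3 stands highest of the three numbers, yet its steps to the others are small and within the scatter, so no order among them is claimed. Compound 4 `Cc1nc(CO)ccc1-c1cnc(NCc2c(F)ccc3c2CCO3)c2cn[nH]c(=O)c12` differs from compound 3 in one place: 6-(hydroxymethyl)-2-methylpyridin-3-yl in place of 1,3-dimethyl-1H-pyrazol-4-yl on an aromatic carbon. For the measured compounds named here, the steps that bear on this are those that vary the group at the same place, a 1.1-fold higher number from compound 1 to compound 3 (0.05 log units; within the scatter) and a 1.9-fold higher number from compound 2 to compound 3 (0.29 log units; within the scatter), and both stay within the scatter. Going by the values given here, no measured step swaps a five-membered ring for a six-membered one here. Compound 4 is therefore expected to show a 1.2-fold lower number from compound 3 to compound 4 (0.09 log units; within the scatter), a step not beyond the scatter. For compound 4 the estimate in this assay is 22 mL.min-1.g-1, with a range from 10 mL.min-1.g-1 to 50 mL.min-1.g-1.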

Compound 4, intrinsic clearance in microsomes in the Homo sapiens assay: 11 mL.min-1.g-1
Beside the measured number, compound 4's estimate is 2.0-fold (0.30 log units) above it, and the stated range covers the measured number.
By their numbers in the Homo sapiens assay, from the lowest: compounds 4, 2, 1 and 3 (each within the scatter of the next, the first and the last beyond it).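

The 6-(hydroxymethyl)-2-methylpyridin-3-yl group gives this position its first steps beyond the scatter in the Homo sapiens assay: a 2.5-fold lower number from compound 3 to compound 4 (0.39 log units; beyond the scatter) and a 2.2-fold lower number from compound 1 to compound 4 (0.34 log units; beyond the scatter), while a 1.3-fold lower number from compound 2 to compound 4 (0.10 log units; within the scatter). In a physicochemical assay for lipophilicity, using the shake flask method, in phosphate buffer, measured as octanol-water partition, with a stated time of 30 min, at pH 7.4 (on this read-out lower numbers stand for lower lipophilicity and higher numbers for higher lipophilicity), compound 3 gives 2.8 and compound 4 gives 2.4. Set against compound 3, compound 4 pairs lower clearance with lower lipophilicity, a link that one pair can only suggest: the measured distribution coefficient of compound 3, 2.8, and of compound 4, 2.4, a number 0.40 log units lower (beyond the scatter).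

The compounds shown leave open whether the six-membered ring or the hydroxymethyl carries the step. They also leave open what a methoxymethyl or aminomethyl group would give in its place.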